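The source may hold more compounds than are shown below. What is called first, only, known or untested is meant among the compounds shown, and "the series" means these compounds.

Compound 3, `CCCCCCCCCCCCNC(=O)[C@H]1OC(n2cnc3c(N)ncnc32)[C@H](O)[C@@H]1O`, carries the longest chain of three amides on a shared core. In an assay on cell membranes for binding affinity to 2-oxoglutarate receptor 1 (Rattus norvegicus), read by radioligand binding (on this read-out lower numbers stand for stronger inhibition and higher numbers for weaker inhibition), compound 3 gives 163 nM, the highest of the three numbers. Compound 1, `CCCCNC(=O)[C@H]1OC(n2cnc3c(N)ncnc32)[C@H](O)[C@@H]1O`, gives 17 nM, and compound 2, `CCCCCCCCCNC(=O)[C@H]1OC(n2cnc3c(N)ncnc32)[C@H](O)[C@@H]1O`, gives 31 nM. The measured steps all concern chain length: a 1.8-fold higher number from compound 1 to compound 2 (0.26 log units; within the scatter), a 9.6-fold higher number from compound 1 to compound 3 (0.98 log units; beyond the scatter), and a 5.3-fold higher number from compound 2 to compound 3 (0.72 log units; beyond the scatter). Lengthening the chain raised the number, clearly so for the larger additions.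

Compound 4, `CC(=O)NCCCCCCCCNC(=O)[C@H]1OC(n2cnc3c(N)ncnc32)[C@H](O)[C@@H]1O`, differs from compound 3 by acetamido in place of butyl on a saturated chain carbon, eight bonds along the chain from an amide-type nitrogen. As the counted difference shows, the group entering has as many heavy atoms as the group leaving, so chain length is unchanged; a hydrogen-bond donor and acceptor now sit at the chain end instead. Within the data shown here, no measured step makes such a swap, so the chain-length steps only fix where compound 3 stands and offer no direct guide. For compound 4 a step of a 1.4-fold lower number from compound 3 to compound 4 (0.13 log units; within the scatter) is expected, within the scatter. Compound 4 is therefore estimated at 120 nM, with a range from 30 nM to 500 nM.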

Compound 4, inhibition constant: 10 nM
The estimate for compound 4 lay 12-fold (1.08 log units) above the measured number; measured number below the stated range.
By their numbers in this assay, from the lowest: compounds 4, 1 and 2 (each within the scatter of the next, the first and the last beyond it); then compound 3.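

At unchanged heavy-atom count, acetamido in place of butyl on a saturated chain carbon, eight bonds along the chain from an amide-type nitrogen, gives a 16-fold lower number from compound 3 to compound 4 (1.21 log units; beyond the scatter) in this assay, so what the chain carries matters here as well as how long it is. The same place also gives a 3.1-fold lower number from compound 2 to compound 4 (0.49 log units; beyond the scatter), which means that among these compounds a long chain ending in acetamido does not carry the higher number seen with the plain alkyl chains of compound 2 and compound 3. The step of a 1.7-fold lower number from compound 1 to compound 4 (0.23 log units; within the scatter) cannot be told from the scatter, so the long acetamido chain and the short butyl chain cannot be separated.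

Nothing available here explains the effect of this change. As far as these compounds go, whether an amine or a carboxylic acid in place of acetamido would give a similar number, or whether acetamido on a longer chain would, stays open.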